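The compounds below may be only part of what the source reports. "The series", "measured", "known", "first", "only" and "open" are said of these compounds alone.

Values in a functional assay on A498 cells (Homo sapiens) for cytotoxicity; a lower number here means a stronger inhibitor of growth, a higher number a weaker inhibitor of growth:
- Compound 1 (`COc1ccc(C2=C(c3ccc(SC)cc3)CC3CCCN3C2=O)cc1Br`) gives 600 nM
- Compound 2 (`COc1ccc(C2=C(c3ccc(SC)cc3)CC3CCCN3C2=O)cc1C`) gives 400 nM
- Compound 3 (`COc1ccc(C2=C(c3ccc(SC)cc3)CC3CCCN3C2=O)cc1`) gives 800 nM

Compound 3 , at 800 nM, lies within the scatter of both others, with a 1.3-fold higher number from compound 1 to compound 3 (0.12 log units; within the scatter) and a 2.0-fold higher number from compound 2 to compound 3 (0.30 log units; within the scatter). Compound 4 (`CSc1ccc(C2=C(c3ccc(C)cc3)C(=O)N3CCCC3C2)cc1`) has 4-methylphenyl in place of 4-methoxyphenyl, the change lying para to a large group: methyl in place of methoxy on an aromatic carbon. Going by the values given here, no measured step touches this methoxy, which all three measured compounds carry. Among the compounds with values here, the only guide is the exchange of bromo, methyl and hydrogen elsewhere, including a 1.5-fold lower number from compound 1 to compound 2 (0.18 log units; within the scatter). In this assay a modest rise in the number is expected, though the data fix no direction. The expected change is a 1.9-fold higher number from compound 3 to compound 4 (0.27 log units; within the scatter). For compound 4 the estimated value is 1500 nM, within an expected range of 400 nM to 6000 nM.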

Compound 4, concentration for 50% growth inhibition: 4000 nM
Beside the measured number, compound 4's estimate is 2.7-fold (0.43 log units) below it; the measured number falls inside the stated range.
By their numbers in this assay, from the lowest: compounds 2, 1 and 3 (each within the scatter of the next); then compound 4.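

In this assay, the methoxy of the 4-methoxyphenyl group matters where the exchanges of bromo, methyl and hydrogen among compound 1, compound 2 and compound 3 did not register: methyl in its place gives a 5.0-fold higher number from compound 3 to compound 4 (0.70 log units; beyond the scatter). The larger replacements of the whole ring point the same way, with a 10-fold higher number from compound 2 to compound 4 (1.00 log units; beyond the scatter) and a 6.7-fold higher number from compound 1 to compound 4 (0.82 log units; beyond the scatter). Nothing available accounts for this rise. From the compounds shown here alone, whether hydroxy, ethoxy or an amine in place of the methoxy would stay near compound 3 or rise as methyl does remains open.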